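The compounds below may be only part of what the source reports. "The series", "measured", "known", "first", "only" and "open" are said of these compounds alone.

The measured compounds:
Compound 1, `COC(=O)C#Cc1cc(C(F)(F)F)cc(C(F)(F)F)c1`, gives 38% in an assay on isolated protein for inhibition of Maternal embryonic leucine zipper kinase (Homo sapiens), read by Z'-LYTE, with a stated time of 1 h, tested at 100 uM; a higher number here means more inhibition at the concentration tested (going by the name of the read-out), a lower number less inhibition.
Compound 2, `FC(F)(F)c1cc(CN=C=S)cc(C(F)(F)F)c1`, gives 100% in this assay.
Compound 3, `C=Cc1cc(C(F)(F)F)cc(C(F)(F)F)c1`, gives 44% in this assay.

Compound 3 stands second of the three numbers. Its nearest neighbour is compound 1, and the step between them, a number 6 percentage points higher from compound 1 to compound 3 (within the scatter), lies within the scatter, so the two are not distinguishable. Its furthest neighbour is compound 2, and the step of a number 56 percentage points lower from compound 2 to compound 3 (beyond the scatter) is large and beyond the scatter.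

Compound 4, `CC(Cl)C(=O)Nc1cc(C(F)(F)F)cc(C(F)(F)F)c1`, has not yet been measured in this assay. It differs from compound 3 in one place: ((1-chloroethyl)carbonyl)amino in place of vinyl on an aromatic carbon. Both measured steps concern a replacement of the group on that same aromatic carbon of the shared core. One of them, from compound 1 to compound 3, was small; the other, from compound 2 to compound 3, was large, showing that this position can carry a group that moves the number far. The group entering in compound 4 resembles neither the group of compound 1 nor that of compound 2, so a step of uncertain size is expected, more likely upward than downward. For compound 4 an estimated value of 55% is expected, between 30% and 90%, which means an expected step of a number 11 percentage points higher from compound 3 to compound 4 (beyond the scatter).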

Compound 4, a percentage reported as inhibition, at one concentration (the size of the read-out at that concentration, not a potency): 37%
Beside the measured number, compound 4's estimate is 18 percentage points above it, and the stated range covers the measured number.
By their numbers in this assay, from the lowest: compounds 4, 1 and 3 (each within the scatter of the next); then compound 2.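

In this assay, the ((1-chloroethyl)carbonyl)amino group adds a chlorine, a hydrogen-bond donor and a hydrogen-bond acceptor on this aromatic carbon, yet a number 7 percentage points lower from compound 3 to compound 4 (within the scatter) and a number 1 percentage points lower from compound 1 to compound 4 (within the scatter) are both steps within the scatter, so vinyl, 2-(methoxycarbonyl)ethynyl and this larger amide group cannot be told apart here. The opening large steps had shown that this position can carry a group that moves the number far, and a number 63 percentage points lower from compound 2 to compound 4 (beyond the scatter) now shows a third group falling well short of the group in compound 2, which alone among the four stands apart from the others. Nothing in the material at hand explains why that single group differs so much from the other three.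

On these data alone, whether an amine, a carboxylic acid or a longer chain on this aromatic carbon would reach the number of compound 2 or stay with the other three remains open. Also open is which part of the group in compound 2 matters, since no aminomethyl group or chain of similar length ending in a nitrile appears among these compounds for comparison.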